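Notes on the amide substituent of compound 2

A few compounds are considered here, and "the series" means these few. Any claim that something is new, unique, unknown or untested is made for them only; others in the source may bear on it.

In an ADME assay on liver (Mus musculus, strain BALB/c) for metabolic stability, read by HPLC, using microsomes, with a stated time of 40 min, tested at 2 uM (a lower number here means slower removal, a higher number faster removal of the compound), compound 1 `O=C(O)CCc1nnc(C(=O)Nc2cccc(-c3ccc(F)cc3)c2)s1` gives 8 mL.min-1.g-1 as the lower number. Compound 2 `O=C(O)CCc1ccc(OCc2nnc(C(=O)Nc3ccccc3F)s2)cc1` gives 241 mL.min-1.g-1 as the higher of the two numbers, a gap beyond the scatter. Compound 3 `O=C(O)CCc1ccc(OCc2nnc(C(=O)Nc3cccc(Cl)c3)s2)cc1` carries one change from compound 2 (3-chlorophenyl in place of 2-fluorophenyl on an amide-type nitrogen): 3-chlorophenyl in place of 2-fluorophenyl on an amide-type nitrogen. For the measured compounds named here, no measured pair shows this change. In this assay no step beyond the scatter is expected, and no direction is favoured. The expected step runs a 1.0-fold higher number from compound 2 to compound 3 (0.02 log units; within the scatter) and stays within that scatter. Compound 3 is estimated at 250 mL.min-1.g-1 (range 100 mL.min-1.g-1 to 600 mL.min-1.g-1).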

Compound 3, intrinsic clearance in microsomes in the Mus musculus assay: 126 mL.min-1.g-1
The estimate for compound 3 lay 2.0-fold (0.30 log units) above the measured number; measured number inside the range.
By their numbers in the Mus musculus assay, from the lowest: compound 1; then compounds 3 and 2 (each within the scatter of the next).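

In the Mus musculus assay, 3-chlorophenyl in place of 2-fluorophenyl on an amide-type nitrogen gives a 1.9-fold lower number from compound 2 to compound 3 (0.28 log units; within the scatter), so this position accepts the change without a clear shift in removal. In a physicochemical assay for lipophilicity, read by LC-MS, at pH 7.4 (on this read-out higher numbers stand for higher lipophilicity and lower numbers for lower lipophilicity), compound 2 gives 0.95 and compound 3 gives 1.46. In the physicochemical assay the same change does register, with higher lipophilicity for the 3-chlorophenyl compound: the measured distribution coefficient of compound 2, 0.95, and of compound 3, 1.46, a number 0.51 log units higher (beyond the scatter). In this single pair, that gain comes with no step beyond the scatter in the Mus musculus assay.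

This pair cannot separate the effect of the halogen from that of where it sits. As far as these compounds go, how a 3-methoxyphenyl or pyridyl group would behave on this nitrogen remains open.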